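A few compounds are considered here, and "the series" means these few. Any claim that something is new, unique, unknown or untested is made for them only; others in the source may bear on it.

Measured in an ADME assay on cells (Homo sapiens) for cytotoxicity, read by resazurin assay, with a stated time of 5 days; on this read-out higher numbers stand for lower toxicity in this test and lower numbers for higher toxicity in this test:
- compound 1 `COc1ccc(-c2nc(CCc3cccc(Cl)c3)nc3ccsc23)cn1`: > 50000 nM (a limit)
- compound 2 `COc1ccc(-c2nc(CSc3cccc(Cl)c3Cl)nc3ccsc23)cn1`: > 50000 nM (a limit)
- compound 3 `COc1ccc(-c2nc(CNc3cccc(Cl)c3)nc3ccsc23)cn1`: > 50000 nM (a limit)

Compound 3 has no number, only a limit, and it shares that place with compound 1 and compound 2: the limit of > 50000 nM in this assay, at which 3 of the 3 values shown sit. Compound 4 `COc1ccc(-c2nc(CC(O)c3cccc(Cl)c3)nc3ccsc23)cn1` differs from compound 3 by one change: (3-chlorophenyl)(hydroxy)methyl in place of (3-chlorophenyl)amino on a saturated chain carbon bound to an aromatic carbon. Among the compounds with values here, two measured steps bear on this change: a step that the two limits leave unreadable from compound 1 to compound 3 and a step that the two limits leave unreadable from compound 2 to compound 3. Neither gives a size to carry over. Within the data shown here, with the limit of > 50000 nM in this assay, at which 3 of the 3 values shown sit, as the only guide, no step beyond the scatter is expected in this assay, in either direction. The expected step is a number no higher from compound 3 to compound 4 (the limit leaves the size open). For compound 4 the estimate is 50000 nM, with an expected range of 20000 nM to 100000 nM.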

Compound 4, half-maximal cytotoxic concentration: 31000 nM
Beside the measured number, compound 4's estimate is 1.6-fold (0.21 log units) above it; the range from low to high includes it.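

Only compound 4 gives a number in this assay; the rest of the series stays at a limit: the limit of > 50000 nM in this assay, at which 3 of the 4 values shown sit.

With a hydroxy group on the chain, the result reads as an at least 1.6-fold lower number from compound 1 to compound 4 (0.20 log units; that floor lies within the scatter), as an at least 1.6-fold lower number from compound 2 to compound 4 (0.20 log units; that floor lies within the scatter) and as an at least 1.6-fold lower number from compound 3 to compound 4 (0.20 log units; that floor lies within the scatter). Each is a floor set by a limit, so the full size of each step stays open, and none is shown to go beyond the scatter.

The steps among compound 1, compound 2 and compound 3 cannot be read. On these data alone, what a carboxylic acid, a dimethylamino group or a longer chain at this place would give in this assay remains open.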